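Varying the aryl substituent on the shared core: cytotoxicity in PC-12 cells

The source may hold more compounds than are shown below. What is called first, only, known or untested is meant among the compounds shown, and "the series" means these compounds.

Compound 1 `Cc1ccc(-n2nc(-c3ccc(C(F)(F)F)cc3O)nc2-c2ccccc2O)cc1`: 71.5%
Compound 2 `CC(C)(C)c1ccc(-n2nc(-c3ccc(C(F)(F)F)cc3O)nc2-c2ccccc2O)cc1`: 67.3%
Compound 3 `Oc1cc(C(F)(F)F)ccc1-c1nc(-c2ccccc2O)n(-c2ccc(C(F)(F)F)cc2)n1`: 70.7%

The three measured compounds share one core and differ only in the group carried by the aryl ring on the triazole nitrogen. In a functional assay on PC-12 cells (Rattus norvegicus) for cytotoxicity, read by MTT assay, with stated times of 2 h and 24 h, tested at 1 uM (a higher number here means a stronger effect of the compound at the concentration tested, a lower number a weaker effect), compound 1 gives 71.5%, compound 2 gives 67.3% and compound 3 gives 70.7%. Compound 3 stands second of the three numbers, but all three lie close together: the step of a number 0.8 percentage points lower from compound 1 to compound 3 (within the scatter) and the step of a number 3.4 percentage points higher from compound 2 to compound 3 (within the scatter) are both within the scatter, as is the step of a number 4.2 percentage points lower from compound 1 to compound 2 (within the scatter). So methyl, tert-butyl and trifluoromethyl at this position give effectively the same read-out.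

Compound 4 `Oc1cc(C(F)(F)F)ccc1-c1nc(-c2ccccc2O)n(-c2ccc(OC(F)(F)F)cc2)n1` carries a further change at the same place: trifluoromethoxy in place of trifluoromethyl on an aromatic carbon. Within the data shown here, no measured step covers this exact exchange. Among the measured compounds shown here, what the data do show is that three different groups at this position left this assay unchanged beyond the scatter, and that is the only guide available.

On that basis compound 4 is expected to show a step of a number 0.7 percentage points lower from compound 3 to compound 4 (within the scatter), that is, nothing beyond the scatter. Compound 4 is therefore estimated at 70%, with a range from 60% to 80%.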

Compound 4, a percentage reported as activity, at one concentration (the size of the read-out at that concentration, not a potency): 65.5%
Compound 4: the middle estimate sits 4.5 percentage points above what was measured, and the stated range covers the measured number.
By their numbers in this assay, from the lowest: compounds 4, 2, 3 and 1 (each within the scatter of the next).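

With compound 4, a fourth group is tested at this position, and the exchange of trifluoromethyl for trifluoromethoxy adds an oxygen and a hydrogen-bond acceptor to the group. In this assay this exchange gives a number 5.2 percentage points lower from compound 3 to compound 4 (within the scatter) and the replacement of tert-butyl gives a number 1.8 percentage points lower from compound 2 to compound 4 (within the scatter), while the replacement of methyl gives a number 6 percentage points lower from compound 1 to compound 4 (within the scatter) and so also stays inside the usual spread of repeats. The range of groups that leave the read-out within the scatter at this position therefore now extends to one carrying an oxygen, and the four compounds cannot be told apart or placed in a real order, but no measurement given here explains this level behaviour.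

As far as these compounds go, it remains open whether an amine, a carboxylic acid or a longer alkyl chain at this position would also stay within the scatter of these four compounds. The compounds shown also leave open whether replacing either hydroxyl group on the shared core with a methoxy group would move the read-out beyond the scatter.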